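Trimming a methoxy group from compound 2

The source may report more compounds than this note shows. Statements on the series, on what has been measured and on what is new or still open speak of the compounds shown alone.

Measured so far:
- compound 1 `COc1ccc(-c2cc(/C=C/C(=O)c3ccc(N)cc3)[nH]n2)cc1`: 86%
- compound 2 `COc1cc(-c2cc(/C=C/C(=O)c3ccc(N)cc3)[nH]n2)cc(OC)c1OC`: 102%
- compound 3 `COc1cc(-c2cc(/C=C/C(=O)c3ccc(Cl)c(Cl)c3)[nH]n2)cc(OC)c1OC`: 95%

In a functional assay on Malme-3M cells (Homo sapiens) for cytotoxicity, read by sulforhodamine B assay, with a stated time of 48 h, tested at 0.1 uM (on this read-out higher numbers stand for a weaker effect at the one concentration tested and lower numbers for a stronger effect), compound 2 gives 102%, the highest of the three numbers, meaning the weakest effect on the cells at this concentration. Compound 3 sits closest, and that change was a number 7 percentage points lower from compound 2 to compound 3 (within the scatter). Compound 1, the furthest away, gives 86% in this assay, a number beyond the scatter from compound 2; it differs from compound 2 in more than one place, so its two values can only be set side by side.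

Compound 4 `COc1ccc(-c2cc(/C=C/C(=O)c3ccc(N)cc3)[nH]n2)cc1OC` has not been measured. It differs from compound 2 in one place: hydrogen in place of methoxy on an aromatic carbon. Among the compounds with values here, no measured step changes a methoxy group, so the only guide is that compound 1, which carries one methoxy group where compound 2 carries three, lies lower. Compound 4 sits between these two in methoxy count, so a modest downward step is expected, a number 8 percentage points lower from compound 2 to compound 4 (within the scatter), with a wide range. Compound 4 is expected to give 94%, between 80% and 108%.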

Compound 4, a percentage reported as activity, at one concentration (the size of the read-out at that concentration, not a potency): 108%
Compound 4: middle estimate off by 14 percentage points, on the low side; measured number inside the range.
By their numbers in this assay, from the lowest: compounds 1, 3, 2 and 4 (each within the scatter of the next, the first and the last beyond it).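

In this assay, hydrogen in place of methoxy on this aromatic carbon gives a number 6 percentage points higher from compound 2 to compound 4 (within the scatter), so this methoxy group of compound 2 can be removed without a shift that stands clear of the usual scatter. Adding a methoxy group to the same ring gives a clearer result, a number 22 percentage points higher from compound 1 to compound 4 (beyond the scatter), which is the first single-place methoxy change shown to go beyond the scatter, toward a weaker effect at the one concentration tested. Thus, in this small set, a methoxy change on this ring can matter or not depending on which one is made, and no supporting data here offer an explanation.

As far as these compounds go, it remains open whether a hydroxyl group or an ethoxy chain on this carbon would read like hydrogen or like methoxy. From the compounds shown here alone, the same methoxy change also remains untested against the 3,4-dichlorophenyl group on the carbonyl carbon.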